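Aryl swap on the ring nitrogen: outlook for compound 4

This account rests on a few compounds, and the source may have more. Where it says the series, first, only, none or still open, it means among the compounds named here.

The three measured compounds, compound 1 `C#Cc1cccc(Nc2ncnc3cc(OC)c(OCCCCC(=O)Nc4ccc(S(N)(=O)=O)cc4)cc23)c1`, compound 2 `COc1cc2ncnc(Nc3ccc(F)cc3)c2cc1OCCCCC(=O)Nc1ccc(S(N)(=O)=O)cc1` and compound 3 `NS(=O)(=O)c1ccc(NC(=S)Nc2ccc3ncnc(Nc4ccc(Cl)c(C(F)(F)F)c4)c3c2)cc1`, sit close together in a functional assay on A-431 cells (Homo sapiens) for antiproliferative activity, read by MTT assay, with a stated time of 72 h; on this read-out lower numbers stand for stronger inhibition and higher numbers for weaker inhibition. Compound 1 gives 17700 nM, compound 2 gives 18600 nM and compound 3 gives 18200 nM; on these numbers compound 3 stands second highest of the three, though within the scatter of both others. Compound 4 `CCc1ccc(Nc2ncnc3ccc(NC(=S)Nc4ccc(S(N)(=O)=O)cc4)cc23)cc1` differs from compound 3 by 4-ethylphenyl in place of 4-chloro-3-(trifluoromethyl)phenyl on a nitrogen on an aromatic ring. Within the data shown here, the one measured step at the same kind of position, a 1.1-fold higher number from compound 1 to compound 2 (0.02 log units; within the scatter), changed nothing beyond the scatter, so the aryl group on this nitrogen made no visible difference in the single comparison available. The step of a 1.0-fold lower number from compound 3 to compound 4 (0.00 log units; within the scatter) is therefore expected to be none beyond the scatter. Compound 4 is expected to give 18000 nM, in the range 9000 nM to 36000 nM.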

Compound 4, half-maximal inhibitory concentration: 38400 nM
Estimate against measurement, compound 4: 2.1-fold (0.33 log units) below, and the stated range ends below it.
By their numbers in this assay, from the lowest: compounds 1, 3 and 2 (each within the scatter of the next); then compound 4.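

In this assay, the aryl group on this nitrogen can move the number: the change to 4-ethylphenyl gives a 2.1-fold higher number from compound 3 to compound 4 (0.32 log units; beyond the scatter) and so passes the scatter. The earlier step, a 1.1-fold higher number from compound 1 to compound 2 (0.02 log units; within the scatter), involved a different pair of aryl groups on compounds with a different side chain, so it did not show this. Nothing available bears on the reason for the new step.

As far as these compounds go, it remains open whether the step follows the loss of the chlorine, the loss of the trifluoromethyl or the gain of the ethyl. A phenyl carrying only a chlorine, or one carrying an amine or a carboxylic acid, would help separate these.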